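A methyl on the amide nitrogen of compound 1

A few compounds are considered here, and "the series" means these few. Any claim that something is new, unique, unknown or untested is made for them only; others in the source may bear on it.

Values in a functional assay on L02 cells (Homo sapiens) for inhibition (on this read-out higher numbers stand for weaker inhibition and lower numbers for stronger inhibition), are:
- Compound 1 (`O=C(CC(CC(=O)NC1Cc2ccccc2C1)c1ccccc1)NCCN1CCCC1`): > 100000 nM
- Compound 2 (`CCN(CC)CCNC(=O)CC(CC(=O)NC1Cc2ccccc2C1)c1ccccc1`): > 100000 nM

Compound 1 reads > 100000 nM and that is a limit of the assay, not a number. Compound 2 reads > 100000 nM and that too is only a limit. Both compounds therefore sit at one shared boundary (the limit of > 100000 nM in this assay, at which 2 of the 2 values shown sit), and neither has a true value to measure from.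

Compound 3 (`CN(C(=O)CC(CC(=O)NCCN1CCCC1)c1ccccc1)C1Cc2ccccc2C1`) keeps the core of compound 1 and makes one change: methyl in place of hydrogen on an amide-type nitrogen. Going by the values given here, only one measured step is available (a step that the two limits leave unreadable from compound 1 to compound 2). It concerns a different place in the molecule, and its size cannot be read, so it offers no size to carry over to the new change. Among the compounds with values here, nothing measured so far points to a gain in inhibition, and the assay will most likely report only a limit again. No change beyond the usual scatter is expected, and the expected step is small (a number no higher from compound 1 to compound 3 (the limit leaves the size open)). Compound 3 is estimated at (100000 nM), with an expected range from (50000 nM) to (200000 nM).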

Compound 3, half-maximal inhibitory concentration: > 100000 nM
Compound 3: only a limit was reported (the forecaster's own chance of this, stated with the estimate: 85%); the middle value lies on the limit itself.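

In this assay compound 3 reads > 100000 nM, which is a limit and not a number. The step from compound 1 to compound 3 therefore cannot be read, and all three compounds share one boundary: the limit of > 100000 nM in this assay, at which 3 of the 3 values shown sit. The compounds shown leave open whether the methyl or the diethylamino group changes inhibition at all.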